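The source may hold more compounds than are shown below. What is called first, only, known or untested is meant among the compounds shown, and "the series" means these compounds.

Working notes on the tellurium-for-selenium series in a functional assay on A-431 cells (Homo sapiens) for cytotoxicity, read by MTT assay, with a stated time of 24 h; on this read-out higher numbers stand for weaker inhibition and lower numbers for stronger inhibition.

Compound 2 `COc1ccc(N(CC(=O)NCCC[Se]c2ccccc2)C(=O)CNC(=O)OC(C)(C)C)cc1` is the selenium member on the shared core of compound 1 and compound 2. In this assay compound 2 gives only >= 100000 nM, which is a limit of the assay and not a number. Compound 1 `COc1ccc(N(CC(=O)NCCC[Te]c2ccccc2)C(=O)CNC(=O)OC(C)(C)C)cc1` differs from compound 2 by a group of 7 heavy atoms (6 carbon, 1 tellurium; one six-membered aromatic ring of carbon only) in place of a group of 7 heavy atoms (6 carbon, 1 selenium; one six-membered aromatic ring of carbon only), on a saturated chain carbon, three bonds along the chain from an amide-type nitrogen. In this assay compound 1 gives 5000 nM. The step is an at least 20-fold lower number from compound 2 to compound 1 (1.30 log units; beyond the scatter); its size is known only as a bound because compound 2 sits at the limit of >= 100000 nM in this assay, at which 1 of the 3 values shown sits.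

Compound 3 `COc1ccc(N(CC(=O)NCCC[Se]c2ccccc2)C(=O)CCSC2=C(C)C(=O)c3ccccc3C2=O)cc1` keeps the selenium arm of compound 2 on a different core; the difference between the two cores is not broken down here. In this assay compound 3 gives 17000 nM, the highest number among the measured compounds and beyond the scatter from compound 1.

Compound 4 `COc1ccc(N(CC(=O)NCCC[Te]c2ccccc2)C(=O)CCSC2=C(C)C(=O)c3ccccc3C2=O)cc1` is not yet measured. It differs from compound 3 by a group of 7 heavy atoms (6 carbon, 1 tellurium; one six-membered aromatic ring of carbon only) in place of a group of 7 heavy atoms (6 carbon, 1 selenium; one six-membered aromatic ring of carbon only), on a saturated chain carbon, three bonds along the chain from an amide-type nitrogen, at a place worded exactly as for the pair compound 2 to compound 1, so it is the same change made on the second core. Because that change gave an at least 20-fold lower number from compound 2 to compound 1 (1.30 log units; beyond the scatter) on the first core, a drop of the same direction is expected on the second core, though set smaller than the measured bound; for compound 4 the expected step is an 8.5-fold lower number from compound 3 to compound 4 (0.93 log units; beyond the scatter). For compound 4 in this assay a value of about 2000 nM is estimated, with 500 nM to 8000 nM as the expected range.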

Compound 4, half-maximal inhibitory concentration: 1000 nM
For compound 4 the middle estimate is 2.0-fold (0.30 log units) above the measured one, and the stated range covers the measured number.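

In this assay, the tellurium group in place of the selenium group, on a saturated chain carbon, three bonds along the chain from an amide-type nitrogen, gives a 17-fold lower number from compound 3 to compound 4 (1.23 log units; beyond the scatter), so on both cores shown the change lowers the number, by a margin beyond the scatter: the same change on two cores in this assay, an at least 20-fold lower number (1.30 log units; beyond the scatter) from compound 2 to compound 1 and a 17-fold lower number (1.23 log units; beyond the scatter) from compound 3 to compound 4; the limit leaves it open whether they differ

Compound 2 gives a limit of the assay and not a number, so the step on the first core is only a bound: the limit of >= 100000 nM in this assay, at which 1 of the 4 values shown sits.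

The two steps show that the direction of the change carries from one core to the other in these two pairs, but they do not show that its size carries over, nor that it would hold on any third core, and they give no reason for the drop in number.

The compounds shown leave open whether the same drop appears with a group of sulfur in place of selenium, with a longer chain, or with an amine or a carboxylic acid on the phenyl ring of the arm. They also leave open how each core on its own contributes to the value, since the difference between the two cores is not broken down here.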